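The compounds below may be only part of what the source reports. "The series", "measured", "known", "first", "only" and "open" are said of these compounds alone.

Measured so far in a functional assay on RPMI8266 cells (Homo sapiens) for inhibition, read by sulforhodamine B assay, with a stated time of 48 h; on this read-out lower numbers stand for stronger inhibition of growth and higher numbers for weaker inhibition of growth:

compound 1 `Nc1cc(N)c2nc(-c3ccccc3)c(NCc3ccc(Cl)c(Cl)c3)nc2c1`: 1660 nM
compound 2 `CCOC(=O)[C@H](CCC(=O)O)NC(=O)c1ccc(Sc2nc3cc(N)cc(N)c3nc2-c2ccccc2)cc1`: 339 nM
compound 3 `Nc1cc(N)c2nc(-c3ccccc3)c(Sc3ccc(Cl)c(Cl)c3)nc2c1`: 3800 nM

Among these three numbers compound 1 stands second highest. Its nearest neighbour is compound 3, which gives a higher number, and that gap lies beyond the usual scatter. Furthest away is compound 2, which gives a lower number, again beyond the scatter. Compound 2 and compound 3 each differ from compound 1 in more than one place, so neither pair gives a clean single-point step.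

Compound 4 `COc1ccc(CNc2nc3cc(N)cc(N)c3nc2-c2ccccc2)cc1OC` has not yet been run in this assay . Against compound 1 the change is 3,4-dimethoxyphenyl in place of 3,4-dichlorophenyl on a saturated chain carbon bound to a nitrogen on an aromatic ring. For the measured compounds named here, no measured pair shows this change on its own, so nothing here directly calibrates it. The linker and the shared core are unchanged, and the new group keeps the same ring size and substitution count, so a large move in either direction is not expected. The estimated step from compound 1 to compound 4 is a 1.5-fold higher number from compound 1 to compound 4 (0.18 log units; within the scatter), leaning weakly toward a higher number and likely within the scatter. The expected value for compound 4 in this assay is 2500 nM, with a plausible range from 800 nM to 8000 nM.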

Compound 4, concentration for 50% growth inhibition: 2140 nM
For compound 4 the middle estimate is 1.2-fold (0.07 log units) above the measured one; measured number inside the range.
By their numbers in this assay, from the lowest: compound 2; then compounds 1, 4 and 3 (each within the scatter of the next, the first and the last beyond it).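

In this assay, for the compounds shown here, exchanging 3,4-dichlorophenyl for 3,4-dimethoxyphenyl on a saturated chain carbon bound to a nitrogen on an aromatic ring gives a 1.3-fold higher number from compound 1 to compound 4 (0.11 log units; within the scatter), the only single-point step so far. At this position, the read-out therefore does not separate the two groups, even though the entering group has 10 heavy atoms against 8 and 2 hydrogen-bond acceptors against 0, and its oxygen atoms replace the chlorine atoms of the leaving group. No supporting measurement is available to explain this result.

One step with two substituents changing together cannot show whether either substituent matters alone, or whether the same exchange would read alike on the sulfur-linked compound 3. Also open, on these data alone, is how this position responds to a group of another kind, such as a carboxylic acid or an amine on the ring, or to a longer chain in place of the single saturated carbon.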